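Swapping the Aryl Group on the Triazole Nitrogen

This account rests on a few compounds, and the source may have more. Where it says the series, first, only, none or still open, it means among the compounds named here.

Three compounds share one core and differ only in the aryl group carried on an aromatic nitrogen of the triazole. Compound 1 `N#CC1=C(N)Oc2c(N)cc3nc4ccccc4nc3c2C12C(=O)N(Cc1cnnn1-c1ccc(F)cc1)c1ccccc12` carries a 4-fluorophenyl group; in an ADME assay on L02 cells (Homo sapiens) for antiproliferative activity, read by MTT assay, with a stated time of 48 h (on this read-out lower numbers stand for stronger inhibition and higher numbers for weaker inhibition), compound 1 reaches only the limit of the assay, > 50000 nM. Compound 2 `N#CC1=C(N)Oc2c(N)cc3nc4ccccc4nc3c2C12C(=O)N(Cc1cnnn1-c1ccccc1Br)c1ccccc12` carries a 2-bromophenyl group and gives 29200 nM in this assay. Compound 3 `COc1ccc(-n2nncc2CN2C(=O)C3(C(C#N)=C(N)Oc4c(N)cc5nc6ccccc6nc5c43)c3ccccc32)cc1` carries a 4-methoxyphenyl group, and for compound 3 this assay again reports only the limit, > 50000 nM. So compound 3 stands at the top of what was measured; the limit of > 50000 nM in this assay, at which 2 of the 3 values shown sit, marks where two of the three values sit.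

The change to compound 4 `CCc1cccc(C)c1-n1nncc1CN1C(=O)C2(C(C#N)=C(N)Oc3c(N)cc4nc5ccccc5nc4c32)c2ccccc21` is 2-ethyl-6-methylphenyl in place of 4-methoxyphenyl on an aromatic nitrogen. The measured steps give little guidance: an at least 1.7-fold lower number from compound 1 to compound 2 (0.23 log units; that floor lies within the scatter) and an at least 1.7-fold higher number from compound 2 to compound 3 (0.23 log units; that floor lies within the scatter) both sit at floors within the scatter, while a step that the two limits leave unreadable from compound 1 to compound 3 cannot be read at all. A step of the size an at least 1.2-fold lower number from compound 3 to compound 4 (0.09 log units; that floor lies within the scatter) is therefore expected, with no confident direction beyond the scatter. Compound 4 is estimated at 40000 nM, within 15000 nM to 120000 nM.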

Compound 4, half-maximal inhibitory concentration: > 50000 nM
Compound 4 was reported as a limit; the forecaster's own chance of this, stated with the estimate: 50%; at least 1.2-fold (0.09 log units) between middle value and limit.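

In this assay compound 4 is again only a limit, so the all-carbon 2-ethyl-6-methylphenyl group on this aromatic nitrogen gives no more of a readable number than the oxygen-bearing 4-methoxyphenyl group did. Set against compound 2, the only compound here with a true number, the change gives an at least 1.7-fold higher number from compound 2 to compound 4 (0.23 log units; that floor lies within the scatter), so even this comparison does not separate the two compounds; the steps from compound 1 and from compound 3 to compound 4 cannot be read at all, with limits at both ends. At this position the limit is now the common result, with compound 2 the one exception: the limit of > 50000 nM in this assay, at which 3 of the 4 values shown sit.

With a single true number among the four compounds, no ranking of these aryl groups can be made. Still open, as far as these compounds go, is whether a phenyl group carrying an amine or a carboxylic acid would give a number clearly under the limit.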